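The source may hold more compounds than are shown below. What is called first, only, known or untested is meant among the compounds shown, and "the series" means these compounds.

Measured so far:
compound 1 `CC(C)c1onc(-c2c(Cl)cccc2Cl)c1COc1ccc(-c2ccc3nc(C(=O)O)cnc3c2)cc1` – 690 nM
compound 2 `CCc1cc(C(=O)O)nc2ccc(-c3ccc(OCc4c(-c5c(Cl)cccc5Cl)noc4C(C)C)cc3)cc12` – 32 nM

In a functional assay on CV-1 cells for agonist activity at Bile acid receptor (Homo sapiens), read by a luciferase reporter (on this read-out higher numbers stand for an effect only at larger amounts of compound and lower numbers for an effect already at smaller amounts), compound 2 gives 32 nM, the lower of the two numbers; compound 1 gives 690 nM, a gap beyond the scatter. Compound 3 `CC(C)Oc1cc(C(=O)O)nc2ccc(-c3ccc(OCc4c(-c5c(Cl)cccc5Cl)noc4C(C)C)cc3)cc12` differs from compound 2 by isopropoxy in place of ethyl on an aromatic carbon. For the measured compounds named here, no measured pair shows this change, so its direction is open; the step expected in this assay is a 1.3-fold higher number from compound 2 to compound 3 (0.10 log units; within the scatter), not beyond the scatter. For compound 3 in this assay the estimate is 40 nM, within 10 nM to 160 nM.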

Compound 3, half-maximal effective concentration: 14 nM
Beside the measured number, compound 3's estimate is 2.9-fold (0.46 log units) above it, within the range that was stated.
By their numbers in this assay, from the lowest: compound 3; then compound 2; then compound 1.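

In this assay the position opposite the ring nitrogen takes isopropoxy in place of ethyl with a 2.3-fold lower number from compound 2 to compound 3 (0.36 log units; beyond the scatter) as a modest gain. This position therefore accepts a larger group carrying an oxygen and a hydrogen-bond acceptor without any loss on this read-out. Nothing available here bears on why the number falls.

Still open, on these data alone, is whether the oxygen or the branched chain carries the step. A methoxy, an ethoxy or an amine at this position would separate the two.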